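The source may report more compounds than this note shows. Statements on the series, on what has been measured and on what is new or still open speak of the compounds shown alone.

Compound 3, `COc1ccc(/C=N/NC(=O)c2cccnc2Nc2cccc(C(F)(F)F)c2)cc1OC`, gives 44% in a functional assay on the whole organism (strain Wistar) for inhibition, with Rattus norvegicus as the target, read by paw edema, with a stated time of 3 h, at a dose of 10 mg/kg by the intraperitoneal route (a higher number here means more inhibition at the dose given (going by the name of the read-out), a lower number less inhibition), the second highest of the three numbers measured. Compound 1, `O=C(N/N=C/c1ccc(F)cc1)c1cccnc1Nc1cccc(C(F)(F)F)c1`, gives 41.3% in this assay, and the step of a number 2.7 percentage points higher from compound 1 to compound 3 (within the scatter) is within the scatter. Compound 2, `O=C(N/N=C/c1ccc(O)cc1)c1cccnc1Nc1cccc(C(F)(F)F)c1`, gives 59.5% in this assay, so the step of a number 15.5 percentage points lower from compound 2 to compound 3 (beyond the scatter) is beyond it, as is the step of a number 18.2 percentage points higher from compound 1 to compound 2 (beyond the scatter).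

Compound 4, `COc1cc(/C=N/NC(=O)c2cccnc2Nc2cccc(C(F)(F)F)c2)cc(OC)c1OC`, differs from compound 3 by methoxy in place of hydrogen on an aromatic carbon. Going by the values given here, no measured step bears directly on adding a third methoxy group. Among the compounds with values here, the only step that brings methoxy groups in at all, a number 2.7 percentage points higher from compound 1 to compound 3 (within the scatter), was within the scatter, and the step that moved the number beyond the scatter, a number 15.5 percentage points lower from compound 2 to compound 3 (beyond the scatter), involved a hydroxy group and does not recur here. The step of no change at the digits printed from compound 3 to compound 4 (within the scatter) is therefore expected to stay within the scatter. Compound 4 is estimated at 44%, with a range from 30% to 58%.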

Compound 4, a percentage reported as inhibition, in the whole organism at one dose (the size of the read-out at that dose, not a potency): 28.5%
Estimate against measurement, compound 4: 15.5 percentage points above, outside the stated range (below it).
By their numbers in this assay, from the lowest: compound 4; then compounds 1 and 3 (each within the scatter of the next); then compound 2.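

Putting methoxy in place of hydrogen on this aromatic carbon, ortho to a methoxy group and meta to a large group, gives a number 15.5 percentage points lower from compound 3 to compound 4 (beyond the scatter) in this assay. Going by these compounds alone, the position is therefore not indifferent to this change, which the earlier compounds could not show: the one earlier step that brought in methoxy groups, a number 2.7 percentage points higher from compound 1 to compound 3 (within the scatter), also changed the substitution of the ring as a whole and stayed within the scatter. Nothing shown here accounts for the lower number.

The compounds shown leave open whether the lower number is specific to methoxy or would follow any group on this carbon, such as an amine, a chloro group or a longer ethoxy chain. They also leave open whether it would persist with a hydroxy group on the neighbouring ring positions named above, at doses other than the single one used.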